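Propyl on the shared core: what compound 4 should show

This account rests on a few compounds, and the source may have more. Where it says the series, first, only, none or still open, it means among the compounds named here.

The shared core of compound 1 `Cc1nc(N)c2nc(O)n(Cc3ccccc3)c2n1` carries a methyl on an aromatic carbon of the ring with two nitrogen atoms, and in a functional assay on the whole organism for activation, with Mus musculus as the target (on this read-out higher numbers stand for an effect only at larger amounts of compound and lower numbers for an effect already at smaller amounts), compound 1 gives 3 mg/kg. Compound 3 `CCc1nc(N)c2nc(O)n(Cc3ccccc3)c2n1` carries an ethyl in that place; in this assay compound 3 gives 3 mg/kg, and no change at the digits printed from compound 1 to compound 3 (within the scatter). Compound 2 `Nc1nc(SCc2ccccc2)nc2c1nc(O)n2Cc1ccccc1` carries a benzylsulfanyl there. For compound 2 the result in this assay is only a limit, > 1 mg/kg, not a number. Because of that limit (the limit of > 1 mg/kg in this assay, at which 1 of the 3 values shown sits), a step that the limit leaves unreadable from compound 1 to compound 2, and likewise a step that the limit leaves unreadable from compound 2 to compound 3, so where compound 2 truly stands cannot be read from the numbers shown.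

Compound 4 `CCCc1nc(N)c2nc(O)n(Cc3ccccc3)c2n1` is the compound not yet measured: propyl in place of benzylsulfanyl on an aromatic carbon. Among the measured compounds shown here, of the measured steps, only the one between methyl and ethyl is readable, and since no change at the digits printed from compound 1 to compound 3 (within the scatter), the propyl of compound 4 continues the same series of alkyl groups that has so far produced no readable movement in this assay. The expectation for compound 4 is therefore a value close to those of compound 1 and compound 3, with no step beyond the scatter in either direction. Compound 4 is estimated to give 3 mg/kg in this assay, with a range from 1.5 mg/kg to 6 mg/kg. Relative to the limit of compound 2, this estimate would mean a step that the limit leaves unreadable from compound 2 to compound 4, an expectation only.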

Compound 4, minimum effective dose: 3 mg/kg
Compound 4: middle estimate and measured number agree at the digits printed; measured number inside the range.
By their numbers in this assay, from the lowest: compounds 1, 3 and 4 (each within the scatter of the next).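

On the aromatic carbon between two ring nitrogen atoms, the propyl of compound 4 extends what the methyl and ethyl pair had shown: in this assay there is no change at the digits printed from compound 3 to compound 4 (within the scatter), and likewise no change at the digits printed from compound 1 to compound 4 (within the scatter). The earlier compounds shown here offered a single readable step at this place, whereas compounds 1, 3 and 4 now form a series of three alkyl groups in which neither added chain carbon, nor the two steps taken together, gives a readable movement. Compound 2 remains a limit and not a number, so every step to or from it, including the exchange of benzylsulfanyl for propyl, cannot be read, and the effect of that larger group with its six-membered aromatic ring stays unknown: the limit of > 1 mg/kg in this assay, at which 1 of the 4 values shown sits.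

The compounds shown leave open whether this lack of movement would hold for a longer chain such as butyl or a branched group such as isopropyl at this place. They also leave open whether an amine, a carboxylic acid or a plain hydrogen on this carbon would produce a step beyond the scatter in this assay.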